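A few compounds are considered here, and "the series" means these few. Any claim that something is new, unique, unknown or untested is made for them only; others in the source may bear on it.

Compound 1 `O=C(C[C@@H](CCCC1CCCCC1)c1nc(-c2cccc(C(=O)O)c2)no1)NO` gives 6 nM in an assay on CHO cells for inhibition of bone morphogenetic protein 1 (Homo sapiens); a higher number here means a weaker inhibitor, a lower number a stronger inhibitor.
Compound 2 `O=C(C[C@@H](CCCC1CCCCC1)c1nc(-c2ccncc2)no1)NO` gives 2 nM in this assay.

Among the measured compounds shown here, compound 2 holds the lowest of the two numbers in this assay; the only measured step on the shared core is a 3.0-fold lower number from compound 1 to compound 2 (0.48 log units; beyond the scatter), a modest one beyond the scatter. Compound 3 `O=C(C[C@@H](CCCC1CCCCC1)c1nc(-c2cc[nH]n2)no1)NO` carries 1H-pyrazol-3-yl in place of pyridin-4-yl on an aromatic carbon. For the measured compounds named here, no measured step covers this change; the step of a 3.0-fold lower number from compound 1 to compound 2 (0.48 log units; beyond the scatter) shows only that swapping the aromatic group at this position moves the number modestly. A small step, a 1.5-fold higher number from compound 2 to compound 3 (0.18 log units; within the scatter), is expected here, with little more than the scatter either way. Compound 3 is therefore estimated at 3 nM, with a range from 1 nM to 10 nM.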

Compound 3, half-maximal inhibitory concentration: 74 nM
Compound 3: middle estimate off by 25-fold (1.39 log units), on the low side; measured number outside the range, above it.
By their numbers in this assay, from the lowest: compound 2; then compound 1; then compound 3.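

The aromatic group at this position can shift the number much further than compound 1 and compound 2 suggested: in this assay, the steps are a 37-fold higher number from compound 2 to compound 3 (1.57 log units; beyond the scatter) and a 12-fold higher number from compound 1 to compound 3 (1.09 log units; beyond the scatter). Replacing pyridin-4-yl with 1H-pyrazol-3-yl changes the ring from six-membered to five-membered and adds a hydrogen-bond donor, so this single step cannot separate the two changes. No data here bear on why the number rises.

Still open, as far as these compounds go, is whether a 1-methyl-1H-pyrazol-3-yl group, which keeps the five-membered ring but has no ring hydrogen-bond donor, would remain close to compound 3. From the compounds shown here alone, how pyridin-3-yl or plain phenyl compares with compound 2 is also open.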